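Replacing 4-methoxybenzyl with benzoyl on the ring amine nitrogen

The compounds below may be only part of what the source reports. "The series", "measured", "known", "first", "only" and "open" are said of these compounds alone.

In a physicochemical assay for solubility, with a stated time of 3 days, at pH 7 (on this read-out higher numbers stand for higher solubility and lower numbers for lower solubility), compound 1 `NC(=O)c1ccc2[nH]c(-c3ccc(OCCC4CCCCN4Cc4ccccc4)cc3)nc2c1` gives 155000 nM as its reading, compound 2 `Cc1ccc(CN2CCCCC2CCOc2ccc(-c3nc4cc(C(N)=O)ccc4[nH]3)cc2)cc1` gives 97000 nM and compound 3 `COc1ccc(CN2CCCCC2CCOc2ccc(-c3nc4cc(C(N)=O)ccc4[nH]3)cc2)cc1` gives 84000 nM on the same scale. Compound 3 stands within the scatter of both other measured compounds, with a 1.2-fold lower number from compound 2 to compound 3 (0.06 log units; within the scatter) as the nearer gap and a 1.8-fold lower number from compound 1 to compound 3 (0.27 log units; within the scatter) as the wider one.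

The next case is compound 4 `NC(=O)c1ccc2[nH]c(-c3ccc(OCCC4CCCCN4C(=O)c4ccccc4)cc3)nc2c1`, and the change is benzoyl in place of 4-methoxybenzyl on an amine nitrogen in a ring (benzoyl in place of 4-methoxybenzyl on an amine nitrogen in a ring, next to the ring atom that bears a large group).

The measured steps bear on this only in part. Both a 1.6-fold lower number from compound 1 to compound 2 (0.20 log units; within the scatter) and a 1.8-fold lower number from compound 1 to compound 3 (0.27 log units; within the scatter) exchange a group on an aromatic carbon and stay within the scatter, as does the gap between compound 2 and compound 3. Within the data shown here, none of them alters the attachment to the amine nitrogen, and the series holds no measured compound with a carbonyl there. The size of the coming step is therefore poorly bounded. Judged from the structural change alone, a step beyond the scatter towards a lower number is expected in this assay, estimated as a 7.0-fold lower number from compound 3 to compound 4 (0.85 log units; beyond the scatter) in size. For compound 4 the estimate is 12000 nM, with an expected range from 1500 nM to 70000 nM in this read-out.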

Compound 4, solubility: 18000 nM
Compound 4: the middle estimate sits 1.5-fold (0.18 log units) below what was measured; measured number inside the range.
By their numbers in this assay, from the lowest: compound 4; then compounds 3, 2 and 1 (each within the scatter of the next).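

In this assay, among these compounds, the attachment on the amine nitrogen in a ring is the first place where a change leaves the scatter: benzoyl in place of 4-methoxybenzyl gives a 4.7-fold lower number from compound 3 to compound 4 (0.67 log units; beyond the scatter) and, against the other two benzyl-type groups, benzoyl gives a 5.4-fold lower number from compound 2 to compound 4 (0.73 log units; beyond the scatter) and an 8.6-fold lower number from compound 1 to compound 4 (0.94 log units; beyond the scatter) in the same direction. Compounds 1, 2 and 3 stand within the scatter of each other while compound 4 stands beyond the scatter of all three, so among these four compounds the step goes with the exchange of the benzyl-type attachment for benzoyl and not with the group on the aromatic carbon, and no compound shown goes against this. Nothing available on the series explains the size or the direction of this step.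

Going by these compounds, whether the step belongs to the carbonyl alone or to benzoyl as a whole stays open, and an acetyl or a 4-methoxybenzoyl on the same nitrogen would separate the two. On these data alone, how a phenylsulfonyl or a plain hydrogen on that nitrogen would read on this scale also stays open.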